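What losing one fluoro may do to compound 4

The source may hold more compounds than are shown below. What is called first, only, known or untested is meant among the compounds shown, and "the series" means these compounds.

Three close relatives that share one core have been measured so far. In an ADME assay on BJ cells (Homo sapiens) for cytotoxicity, with a stated time of 72 h (a lower number here means that less compound is needed, a higher number that more compound is needed for the effect), compound 1 `CC(=O)c1ccc(NC(=O)Nc2cc(C)nc3ccccc23)cc1` gives 22000 nM. Compound 2 `Cc1ccc(NC(=O)Nc2cc(C)nc3ccccc23)cc1` reads > 25000 nM, which is a limit of the assay and not a number. Compound 3 `Cc1cc(NC(=O)Nc2ccc(F)c(F)c2)c2ccccc2n1` reads > 25000 nM, which is likewise a limit and not a number. Compound 3 therefore has no exact place on the scale and stands at the limit of > 25000 nM in this assay, at which 2 of the 3 values shown sit.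

Compound 4 `Cc1cc(NC(=O)Nc2ccc(F)cc2)c2ccccc2n1` is still unmeasured. It differs from compound 3 by a single change, hydrogen in place of fluoro on an aromatic carbon.

Among the measured compounds shown here, no measured step makes this same swap. For the measured compounds named here, the only measured step is a different one, methyl in place of acetyl on an aromatic carbon: an at least 1.1-fold higher number from compound 1 to compound 2 (0.05 log units; that floor lies within the scatter). That step offers only weak guidance, but it gives no sign of a large change within this small family. No step beyond the scatter is therefore expected in this assay, and no direction can be favoured. The expected outcome is a step that the limit leaves unreadable from compound 3 to compound 4. For compound 4 the estimate is 27000 nM, with an expected range from 15000 nM to 50000 nM.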

Compound 4, half-maximal effective concentration: > 25000 nM
Compound 4: a limit, no number; the forecaster's own chance of this, stated with the estimate: 80%; the middle value is on the limit's open side.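

Hydrogen in place of fluoro on this ring leaves compound 4 in the same place as compound 3 in this assay, so a single fluoro serves as well as two in keeping the read-out out of the measurable range: the limit of > 25000 nM in this assay, at which 3 of the 4 values shown sit. The steps from compound 3 and from compound 2 to compound 4 cannot be read, as both ends of each are limits. Among the compounds shown here, the one step that can be read is an at least 1.1-fold higher number from compound 1 to compound 4 (0.05 log units; that floor lies within the scatter), so fluoro in place of acetyl shows no change that can be told from noise.

For the compounds shown here, with compound 1 as the only compound that gives an exact number, how far compound 2, compound 3 and compound 4 lie from one another on the scale stays unknown. Going by these compounds, it also stays open whether a different group at this place, such as an amine, a carboxylic acid or a longer chain, would give a number instead of a limit.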